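A few compounds are considered here, and "the series" means these few. Any claim that something is new, unique, unknown or untested is made for them only; others in the source may bear on it.

Going by the values given here, compound 2 `COc1ccc(C(c2ccc(OCCO)cc2)c2cccc3ccccc23)c(OC)c1OC` is the one compound of this set that yields a number in a functional assay on THP-1 cells (Homo sapiens) for inhibition, read by sulforhodamine B assay, with a stated time of 48 h; on this read-out lower numbers stand for stronger inhibition and higher numbers for weaker inhibition: compound 2 gives 16600 nM. Compound 1 `COc1ccc(/C(=N/O)c2cccc3ccccc23)c(OC)c1OC` sits at the limit of > 20000 nM in this assay, at which 2 of the 3 values shown sit, and the reading of compound 1, > 20000 nM, is a limit of the assay and not a number. Compound 3 `CCOC(=O)C(C)C(O)(c1ccc(OC)c(OC)c1OC)c1cccc2ccccc12` likewise gives > 20000 nM in this assay, again a limit. Among the compounds with values here, no step between measured compounds that differ in one place is available here. Compound 4 `COc1ccc(C(c2ccc(OCC(=O)O)cc2)c2cccc3ccccc23)c(OC)c1OC` differs from compound 2 by carboxy in place of hydroxymethyl on a saturated chain carbon bound to an oxygen on an aromatic ring. With nothing measured on a change of this kind, the estimate for compound 4 is 20000 nM, between 8000 nM and 40000 nM. The expected shift a 1.2-fold higher number from compound 2 to compound 4 (0.08 log units; within the scatter) is none beyond the scatter, with a fair chance that only a limit is reported.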

Compound 4, half-maximal inhibitory concentration: > 20000 nM
Compound 4 gave a limit, no number; the forecaster's own chance of this, stated with the estimate: 50%; the middle value sits exactly at the limit.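

Carboxy in place of hydroxymethyl on a saturated chain carbon bound to an oxygen on an aromatic ring gives the first readable step at this position: in this assay it reads as an at least 1.2-fold higher number from compound 2 to compound 4 (0.08 log units; that floor lies within the scatter). From the compounds shown here alone, that figure is only a floor, so the real size of the change stays unknown and could be anything from nothing to a clear loss. Compound 4 thereby joins the compounds that give a limit and not a number: the limit of > 20000 nM in this assay, at which 3 of the 4 values shown sit.

Going by these compounds, it remains open how an amine, an amide or a longer chain ending in hydroxy would read at this place. On these data alone, it also remains open whether any group here would give a number well below that of compound 2.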